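This account rests on a few compounds, and the source may have more. Where it says the series, first, only, none or still open, it means among the compounds named here.

Measured compounds in a functional assay on MCF7 cells (Homo sapiens) for cytotoxicity, read by sulforhodamine B assay, with a stated time of 48 h; a higher number here means a weaker inhibitor, a lower number a stronger inhibitor:

Compound 1, `Cc1ccccc1OS(=O)(=O)c1cccc(NC(=O)NCCCCl)c1`, gives 27000 nM.
Compound 2, `CCc1ccccc1OS(=O)(=O)c1cccc(NC(=O)NCCCCl)c1`, gives 25000 nM.
Compound 3, `CCNC(=O)Nc1ccc(S(=O)(=O)Oc2ccccc2C)cc1`, gives 4500 nM.

Compounds 1 and 2 share one core and differ in a single place: methyl in place of hydrogen on a saturated chain carbon bound to an aromatic carbon. The step between them in this assay is a 1.1-fold lower number from compound 1 to compound 2 (0.03 log units; within the scatter), so the two numbers cannot be told apart. Compound 3 rests on a different core; how that core differs from the core of compound 1 is not broken down here. Its number is the lowest of the three, and its gap to compound 2 and to compound 1 lies beyond the scatter.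

Compound 4, `CCNC(=O)Nc1ccc(S(=O)(=O)Oc2ccccc2CC)cc1`, has not been measured. It relates to compound 3 as compound 2 relates to compound 1: methyl in place of hydrogen on a saturated chain carbon bound to an aromatic carbon. The change occurs twice among these compounds, with the same place each time.

The expected step is a 1.1-fold lower number from compound 3 to compound 4 (0.03 log units; within the scatter), set beside the measured 1.1-fold lower number from compound 1 to compound 2 (0.03 log units; within the scatter). This rests on compound 3 giving 4500 nM and on the earlier pair showing no change to speak of. Compound 4 is therefore estimated at 4200 nM in this assay, with a likely range from 2000 nM to 9000 nM.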

Compound 4, half-maximal inhibitory concentration: 3400 nM
Compound 4: the middle estimate sits 1.2-fold (0.09 log units) above what was measured; the range from low to high includes it.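

In this assay, going from 2-methylphenyl to 2-ethylphenyl gives a 1.3-fold lower number from compound 3 to compound 4 (0.12 log units; within the scatter), so on this core, as on the core of compound 1, the added methyl leaves two numbers that cannot be told apart. The two steps also agree with each other, so the change carries over from one core to the other in the sense that neither core shows a real step: the same change on two cores in this assay, a 1.1-fold lower number (0.03 log units; within the scatter) from compound 1 to compound 2 and a 1.3-fold lower number (0.12 log units; within the scatter) from compound 3 to compound 4, 1.2-fold (0.09 log units) apart, within the scatter of two such steps. This does not show that a step of real size would transfer between the cores, since neither pair has one, and two cores in a single assay give no rule for any other core in the series.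

The compounds shown stop at ethyl, so it remains open whether a longer chain such as propyl, or an amine or a carboxylic acid in place of the ethyl, would move the number in this assay beyond the scatter. If such a group did, it would also remain to be seen whether the step came out the same on both cores.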